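The source may hold more compounds than are shown below. What is called first, only, known or untested is meant among the compounds shown, and "the series" means these compounds.

Compound 1: `COc1ccc2nc(NC(=O)CNC(=O)c3nn(-c4ccc(F)cc4)c(=O)c4ccccc34)sc2c1` — 90 nM
Compound 2: `O=C(CNC(=O)c1nn(-c2ccccc2)c(=O)c2ccccc12)Nc1nc2ccc(Cl)cc2s1` — 30 nM
Compound 3: `COc1ccc(-n2nc(C(=O)NCC(=O)Nc3nc4ccc(Cl)cc4s3)c3ccccc3c2=O)cc1` — 15 nM

In an assay on L cells for inhibition of Protein-serine O-palmitoleoyltransferase porcupine (Mus musculus), read by reporter gene assay, with a stated time of 24 h (on this read-out higher numbers stand for an effect only at larger amounts of compound and lower numbers for an effect already at smaller amounts), compound 3 stands lowest of the three numbers, with compound 2 nearest and compound 1 furthest. Compound 4 `O=C(CNC(=O)c1nn(-c2ccc(F)cc2)c(=O)c2ccccc12)Nc1nc2ccc(Cl)cc2s1` carries the change (fluoro in place of methoxy on an aromatic carbon). Within the data shown here, the only measured step at this position is a 2.0-fold lower number from compound 2 to compound 3 (0.30 log units; within the scatter), which was within the scatter. Among the measured compounds shown here, compound 1, which also carries fluoro at this place but with methoxy rather than chloro on the shared core, gives 90 nM; no single-point step links it to compound 4, so its value can only be noted. The step from compound 3 to compound 4 is therefore expected to be small, a 2.0-fold higher number from compound 3 to compound 4 (0.30 log units; within the scatter), leaving compound 4 near compound 2. The estimate for compound 4 is 30 nM, in the range 12 nM to 80 nM.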

Compound 4, half-maximal effective concentration: 25 nM
Beside the measured number, compound 4's estimate is 1.2-fold (0.08 log units) above it, and the stated range covers the measured number.
By their numbers in this assay, from the lowest: compounds 3, 4 and 2 (each within the scatter of the next); then compound 1.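

In this assay the steps of a 1.7-fold higher number from compound 3 to compound 4 (0.22 log units; within the scatter) and a 1.2-fold lower number from compound 2 to compound 4 (0.08 log units; within the scatter) both lie within the scatter, so hydrogen, fluoro and methoxy on this phenyl ring cannot be told apart. Among these compounds, the step of a 3.6-fold lower number from compound 1 to compound 4 (0.56 log units; beyond the scatter) lies beyond the scatter, making chloro in place of methoxy on the shared core the first single change here to exceed it. Nothing at hand explains either finding. Still open, going by these compounds, is whether an amine or a carboxylic acid on the phenyl ring would also leave the number in place, and whether a longer chain on the shared core would match chloro.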